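The compounds below may be only part of what the source reports. "The series", "measured", "known", "first", "only" and "open" are said of these compounds alone.

Measured so far in a functional assay on DU-145 cells (Homo sapiens) for inhibition, read by MTT assay, with a stated time of 48 h; a higher number here means a weaker inhibitor, a lower number a stronger inhibitor:
compound 1 `CCn1c(/C=C2\SC(=O)N(CC(=O)N3CCCCC3)C2=O)nc2ccccc21`: > 50000 nM
compound 2 `CC(C)n1c(/C=C2\SC(=O)N(CC(=O)N3CCOCC3)C2=O)nc2ccccc21`: > 50000 nM
compound 3 `CCn1c(/C=C2\SC(=O)N(CC(=O)N3CCOCC3)C2=O)nc2ccccc21`: > 50000 nM

The entry of compound 2, > 50000 nM, is a limit and not a number. Among the measured compounds shown here, the other two compounds stand at the same limit, so the series offers no numerical value so far: the limit of > 50000 nM in this assay, at which 3 of the 3 values shown sit.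

The next compound to be measured is compound 4 `CC(C)n1c(/C=C2\SC(=O)N(CC(=O)N3CCCCC3)C2=O)nc2ccccc21`. The structural change from compound 2 is piperidin-1-yl in place of morpholin-4-yl on a carbonyl carbon.

The closest measured step is the same exchange read in the opposite direction: a step that the two limits leave unreadable from compound 1 to compound 3. The other measured step concerns a different place, hydrogen in place of methyl on a saturated chain carbon bound to an aromatic nitrogen and a saturated chain carbon: a step that the two limits leave unreadable from compound 2 to compound 3. Neither step has a readable size. Compound 1, which already carries piperidin-1-yl, gives > 50000 nM, also a limit.

For the measured compounds named here, no measured step therefore supports a real change in this assay, and a further limit is the likeliest report. The expected a number no higher from compound 2 to compound 4 (the limit leaves the size open) stays within the scatter, with no direction expected. For compound 4 the estimated value is 50000 nM, with an expected range of 20000 nM to 100000 nM.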

Compound 4, half-maximal inhibitory concentration: 42200 nM
Beside the measured number, compound 4's estimate is 1.2-fold (0.07 log units) above it; the range from low to high includes it.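

In this assay the exchange of morpholin-4-yl for piperidin-1-yl on a carbonyl carbon now has a readable floor, and the step is an at least 1.1-fold lower number from compound 2 to compound 4 (0.07 log units; that floor lies within the scatter) in this pair, where the earlier pair at this position left the size unreadable. The other place, methyl in place of hydrogen on a saturated chain carbon bound to an aromatic nitrogen and a saturated chain carbon, also becomes readable with piperidin-1-yl present, as an at least 1.1-fold lower number from compound 1 to compound 4 (0.07 log units; that floor lies within the scatter) in this pair. Neither floor establishes a real effect of either change, the steps among compound 1, compound 2 and compound 3 still cannot be read, and compound 4 alone carries a number, while the rest of the series stays at the assay limit: the limit of > 50000 nM in this assay, at which 3 of the 4 values shown sit.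

On these data alone, the true size of both steps stays open, and so does whether either change matters alone or only the two together. Also open, as far as these compounds go, is how the series reads with a piperazin-1-yl or a dimethylamino group on the carbonyl carbon, or with a longer chain on the aromatic nitrogen of the shared core.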